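The source may report more compounds than this note shows. Statements on the series, on what has been measured and on what is new or still open speak of the compounds shown alone.

Within the data shown here, compound 3 `O=C(NCCCCc1ccccc1)c1cccc(C2SCC(=O)N2c2ccccn2)c1` gives 492 mL.min-1.g-1 in an ADME assay on microsomes from liver (Canis lupus familiaris) for metabolic stability, read by LC-MS, using NADPH, with a stated time of 10 min, tested at 0.1 uM (on this read-out lower numbers stand for slow clearance and higher numbers for fast clearance), and stands second highest of the three numbers measured so far. Compound 1 `COc1ccccc1N1C(=O)C(C)SC1c1cccc(C(=O)NCCCCc2ccccc2)c1` gives 1170 mL.min-1.g-1 in this assay, and compound 2 `O=C(NCCCCn1cccn1)c1cccc(C2SCC(=O)N2c2ccccn2)c1` gives 88.9 mL.min-1.g-1. Among the measured compounds shown here, the only single-point step among the measured compounds, a 5.5-fold higher number from compound 2 to compound 3 (0.74 log units; beyond the scatter), changes the end of the chain, not the group on the ring nitrogen.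

Compound 4 `C#Cc1cccc(N2C(=O)CSC2c2cccc(C(=O)NCCCCc3ccccc3)c2)c1` differs from compound 3 by 3-ethynylphenyl in place of pyridin-2-yl on an amide-type nitrogen in a ring. For the measured compounds named here, no measured step alters the group on this amide-type nitrogen in a ring, so the change rests on indirect evidence. Going by the values given here, compound 1 also carries a carbon-only aromatic ring on that nitrogen and gives the highest number in the set, but it differs from compound 3 elsewhere in the core as well, so its two values show only that a carbon-only ring there has gone with a higher number. A modest upward step, a 1.8-fold higher number from compound 3 to compound 4 (0.26 log units; within the scatter), is therefore expected, with wide uncertainty. Compound 4 is estimated at 900 mL.min-1.g-1, within a range from 350 mL.min-1.g-1 to 2200 mL.min-1.g-1.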

Compound 4, intrinsic clearance in microsomes: 973 mL.min-1.g-1
The estimate for compound 4 lay 1.1-fold (0.03 log units) below the measured number, and the stated range covers the measured number.
By their numbers in this assay, from the lowest: compound 2; then compounds 3, 4 and 1 (each within the scatter of the next, the first and the last beyond it).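

Among these compounds, this is the first direct step at the amide-type nitrogen in a ring: with the shared core and the phenyl-ended chain held constant, the change to 3-ethynylphenyl from pyridin-2-yl gives a 2.0-fold higher number from compound 3 to compound 4 (0.30 log units; within the scatter) in this assay. Among the compounds shown here, the indirect hint from compound 1 is therefore not confirmed as a real shift for this pair, whereas the chain-end change gives a 5.5-fold higher number from compound 2 to compound 3 (0.74 log units; beyond the scatter), the only step so far that clears the scatter. No measured property bears on either step, so neither has an assigned cause.

Open, going by these compounds, is whether an unsubstituted phenyl or a morpholine-bearing phenyl on this nitrogen would separate from compound 3 or compound 4. Also open, on these data alone, is whether 3-ethynylphenyl paired with the 1H-pyrazol-1-yl chain end would stay close to compound 2.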